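A Methyl for a Chloro in Compound 1

This account rests on a few compounds, and the source may have more. Where it says the series, first, only, none or still open, it means among the compounds named here.

Compound 1 (`CCOc1ccc(C(=O)NNc2c(Cl)cccc2Cl)cc1`) was tested in a toxicity assay on MDCK cells (Canis lupus familiaris) for cytotoxicity, read by CCK-8 assay, with a stated time of 48 h; on this read-out lower numbers stand for higher toxicity in this test and higher numbers for lower toxicity in this test. There, compound 1 gives > 100000 nM, which is a limit and not a number. Compound 2 (`Cc1ccc(C(=O)NNc2c(Cl)cccc2Cl)cc1`) gives > 100000 nM, also a limit. Compound 3 (`O=C(NNc1c(Cl)cccc1Cl)c1ccccc1`) gives > 100000 nM, again a limit. Compound 1 therefore has no exact position, and the series shows only (the limit of > 100000 nM in this assay, at which 3 of the 3 values shown sit).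

Compound 4 (`CCOc1ccc(C(=O)NNc2c(C)cccc2Cl)cc1`) has methyl in place of chloro on an aromatic carbon, ortho to a large group and meta to a chloro group: methyl in place of chloro on an aromatic carbon. The measured steps are a step that the two limits leave unreadable from compound 1 to compound 2, a step that the two limits leave unreadable from compound 1 to compound 3 and a step that the two limits leave unreadable from compound 2 to compound 3. All three change the ethoxy position rather than a chloro, so none tests this swap directly, and none has a readable size. The expectation rests on compound 1 and its limit of > 100000 nM. The expected result in this assay is a number no higher from compound 1 to compound 4 (the limit leaves the size open), with no step beyond the scatter and no favoured direction. Compound 4 is estimated at 100000 nM, with an expected range of 40000 nM to 200000 nM.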

Compound 4, half-maximal cytotoxic concentration: > 100000 nM
Compound 4 ended at the assay's limit; the forecaster's own chance of this, stated with the estimate: 85%; the middle value sits exactly at the limit.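

No step can be read from compound 1 to compound 4, since both values are limits and not numbers: the limit of > 100000 nM in this assay, at which 4 of the 4 values shown sit.

The compounds shown leave open where any of them would fall beyond that limit, and whether methyl in place of chloro changes that position at all.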